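A Methyl for Two Fluorines on the Phenoxy Arm

A few compounds are considered here, and "the series" means these few. Any claim that something is new, unique, unknown or untested is made for them only; others in the source may bear on it.

Compound 2 `Cc1nn(C)c(Oc2ccc(F)cc2F)c1/C=N\CCCCCCOc1cc2oc(=O)cc(C)c2cc1Cl` carries a 2,4-difluorophenoxy group on the shared core. In a functional assay on SMMC-7721 cells (Homo sapiens) for antiproliferative activity, read by MTT assay, with a stated time of 72 h (on this read-out lower numbers stand for stronger inhibition and higher numbers for weaker inhibition), compound 2 gives only a limit, > 25000 nM. Compound 1 `Cc1nn(C)c(Oc2ccc(I)cc2)c1/C=N\CCCCCOc1cc2oc(=O)cc(C)c2cc1Cl` likewise gives only a limit in this assay, > 25000 nM. Going by the values given here, compound 3 `Cc1nn(C)c(Oc2ccc(Br)cc2)c1/C=N\CCCCCCOc1cc2oc(=O)cc(C)c2cc1Cl` is the one measured compound with a number; in this assay compound 3 gives 3090 nM. Among the compounds with values here, the single measured step that bears on the present question is an at least 8.0-fold lower number from compound 2 to compound 3 (0.90 log units; beyond the scatter), and it shows that exchanging the aryl group on the oxygen on the aromatic ring can carry a compound off the limit (the limit of > 25000 nM in this assay, at which 2 of the 3 values shown sit). Compound 4 `Cc1ccc(Oc2c(/C=N\CCCCCCOc3cc4oc(=O)cc(C)c4cc3Cl)c(C)nn2C)cc1` differs from compound 2 by 4-methylphenyl in place of 2,4-difluorophenyl on an oxygen on an aromatic ring. Whether 4-methylphenyl behaves like 4-bromophenyl cannot be read from these three compounds, so the expectation is cautious. The estimate for compound 4 in this assay is 10000 nM, with a range from 3000 nM to 30000 nM. This estimate means an expected step of an at least 2.5-fold lower number from compound 2 to compound 4 (0.39 log units; beyond the scatter), a modest move in the direction of compound 3, with a real chance that the assay again reports only a limit.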

Compound 4, half-maximal inhibitory concentration: 18600 nM
Beside the measured number, compound 4's estimate is 1.9-fold (0.27 log units) below it; the range from low to high includes it.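

In this assay the 4-methylphenoxy arm gives compound 4 a number, and the step is an at least 1.3-fold lower number from compound 2 to compound 4 (0.12 log units; that floor lies within the scatter), so this exchange cannot yet be told apart from no change at all. Going by these compounds, the true size of that step stays unknown because compound 2 is only a limit: the limit of > 25000 nM in this assay, at which 2 of the 4 values shown sit. The other step shows that the group on this aromatic carbon matters among compounds that give numbers, since methyl in place of bromo brings a 6.0-fold higher number from compound 3 to compound 4 (0.78 log units; beyond the scatter).

On these data alone, whether a chloro, a methoxy or an amine on this aromatic carbon would read closer to compound 3 or to compound 4 stays open. Also open, as far as these compounds go, is how a 4-iodophenyl arm would read on the chain of compound 3, since compound 1 differs from compound 3 in more than one place.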